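Third methoxy on the benzyl group of compound 3

The compounds below may be only part of what the source reports. "The series", "measured", "known", "first", "only" and "open" are said of these compounds alone.

Measured so far:
compound 1 `CCOC(=O)[C@H](CCC(=O)O)NC(=O)c1ccc(CNc2nc3cc(N)cc(N)c3nc2-c2ccccc2)cc1` – < 100000 nM
compound 2 `Nc1cc(N)c2nc(-c3ccccc3)c(NCc3ccc(Cl)c(Cl)c3)nc2c1` – 40700 nM
compound 3 `COc1ccc(CNc2nc3cc(N)cc(N)c3nc2-c2ccccc2)cc1OC` – 41700 nM

In a functional assay on OVCAR-5 cells (Homo sapiens) for inhibition, read by sulforhodamine B assay, with a stated time of 48 h (a lower number here means a stronger inhibitor of growth, a higher number a weaker inhibitor of growth), compound 1 gives only a limit of the assay, < 100000 nM, not a number. Compound 2 `Nc1cc(N)c2nc(-c3ccccc3)c(NCc3ccc(Cl)c(Cl)c3)nc2c1` gives 40700 nM. Compound 3 `COc1ccc(CNc2nc3cc(N)cc(N)c3nc2-c2ccccc2)cc1OC` gives 41700 nM, and a 1.0-fold higher number from compound 2 to compound 3 (0.01 log units; within the scatter) shows that compound 2 and compound 3 lie within the scatter of each other. Compound 4 `COc1cc(CNc2nc3cc(N)cc(N)c3nc2-c2ccccc2)cc(OC)c1OC` is not yet measured; its change from compound 3 is methoxy in place of hydrogen on an aromatic carbon. Among the measured compounds shown here, only one measured step bears on this group of compounds, and it stayed within the scatter, so a small step at most is expected for a 1.0-fold lower number from compound 3 to compound 4 (0.02 log units; within the scatter). Compound 4 is therefore estimated at 40000 nM, within 15000 nM to 100000 nM.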

Compound 4, concentration for total growth inhibition: < 50200 nM
Compound 4: no number, only a limit; the forecaster's own chance of this, stated with the estimate: 20%; the middle value lies beyond the limit too.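

Compound 4 gives only a limit of the assay, < 50200 nM, not a number. The step from compound 3 to compound 4 therefore cannot be read. From the compounds shown here alone, whether the added methoxy shifts growth inhibition in this assay stays open.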